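Swapping the Ether Arm on a Shared Inactive Core

This account rests on a few compounds, and the source may have more. Where it says the series, first, only, none or still open, it means among the compounds named here.

Compound 1 `COc1c(OCc2cnoc2C)cc(O)c2c(=O)cc(-c3ccccc3)oc12` gives > 100000 nM in this assay.
Compound 2 `COc1c(OCc2nc3ccccc3[nH]2)cc(O)c2c(=O)cc(-c3ccccc3)oc12` gives > 100000 nM.
Compound 3 `CN1CCN(CCCCOc2c(O)cc(O)c3c(=O)cc(-c4ccccc4)oc23)CC1` gives > 100000 nM.

In a functional assay on A549 cells (Homo sapiens) for cytotoxicity, read by MTT assay, with a stated time of 48 h (on this read-out lower numbers stand for stronger inhibition and higher numbers for weaker inhibition), the value of compound 1 is a limit of the assay, not a number. The value of compound 2 is likewise a limit. The value of compound 3 is also a limit. All three therefore sit at the limit of > 100000 nM in this assay, at which 3 of the 3 values shown sit. Going by the values given here, the one step between compounds that differ in a single place, a step that the two limits leave unreadable from compound 1 to compound 2, cannot be read because both of its ends are limits.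

Compound 4 `COc1c(OCc2ncc(C)o2)cc(O)c2c(=O)cc(-c3ccccc3)oc12` differs from compound 2 by 5-methyl-1,3-oxazol-2-yl in place of 1H-benzimidazol-2-yl on a saturated chain carbon bound to an oxygen on an aromatic ring. No measured step speaks to this change, and nothing shown moves off the limit. Compound 4 is therefore expected to stay at the limit, estimated at 100000 nM (range 30000 nM to 300000 nM). The expected step is a number no higher from compound 2 to compound 4 (the limit leaves the size open).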

Compound 4, half-maximal inhibitory concentration: > 100000 nM
Compound 4 ended at the assay's limit; the forecaster's own chance of this, stated with the estimate: 80%; the middle value sits exactly at the limit.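

The steps from compound 1 to compound 4 and from compound 2 to compound 4 cannot be read, since each joins two limits rather than numbers: the limit of > 100000 nM in this assay, at which 4 of the 4 values shown sit.

Which ether arm on the shared core, if any, would give a readable number remains open.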